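The source may hold more compounds than are shown below. What is called first, only, known or untested is meant among the compounds shown, and "the series" means these compounds.

Measured compounds in an ADME assay on MT4 cells (Homo sapiens) for cytotoxicity, read by MTT assay; on this read-out lower numbers stand for higher toxicity in this test and higher numbers for lower toxicity in this test:
compound 1 `Cc1ccc(-c2c(C)nc(NC(=O)NC3CCCCC3)c(C)c2C(OC(C)(C)C)C(=O)O)cc1C`, 7900 nM
compound 2 `Cc1ccc(-c2c(C)nc(NC(=O)NC3CCOCC3)c(C)c2C(OC(C)(C)C)C(=O)O)cc1C`, 29000 nM
compound 3 `Cc1ccc(-c2c(C)nc(Nc3nc4ccccc4n3C)c(C)c2C(OC(C)(C)C)C(=O)O)cc1C`, 14000 nM

Compound 1 gives the smallest of the three numbers in this assay, though compound 3 sits within the scatter of it, as a 1.8-fold higher number from compound 1 to compound 3 (0.25 log units; within the scatter) shows; only compound 2 stands clearly apart, with a 3.7-fold higher number from compound 1 to compound 2 (0.56 log units; beyond the scatter).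

Compound 4 `Cc1ccc(-c2c(C)nc(Nc3nc4ccccc4s3)c(C)c2C(OC(C)(C)C)C(=O)O)cc1C` has not been measured. It differs from compound 1 by 1,3-benzothiazol-2-yl in place of cyclohexylcarbamoyl on a nitrogen on an aromatic ring. Going by the values given here, the step that bears most directly on this is the one from compound 1 to compound 3, where a different bicyclic aromatic group took the place of the same cyclohexylcarbamoyl group on the same ring nitrogen, and that step stayed within the scatter: a 1.8-fold higher number from compound 1 to compound 3 (0.25 log units; within the scatter). The step of a 2.1-fold lower number from compound 2 to compound 3 (0.32 log units; beyond the scatter) points the same way, a modest change only. On this basis compound 4 is expected to land close to compound 1, and any movement is estimated to be small, a 1.4-fold higher number from compound 1 to compound 4 (0.14 log units; within the scatter), with no direction claimed beyond the scatter. The estimate for compound 4 in this assay is 11000 nM, within the range 5000 nM to 25000 nM.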

Compound 4, half-maximal cytotoxic concentration: 6600 nM
Estimate against measurement, compound 4: 1.7-fold (0.22 log units) above, within the range that was stated.
By their numbers in this assay, from the lowest: compounds 4, 1 and 3 (each within the scatter of the next, the first and the last beyond it); then compound 2.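

The 1,3-benzothiazol-2-yl group shows that in this assay a group with two aromatic rings and no carbamoyl can stand on this nitrogen in place of cyclohexylcarbamoyl without a change beyond the scatter (a 1.2-fold lower number from compound 1 to compound 4 (0.08 log units; within the scatter)). The two aromatic groups do not read alike, though: 1,3-benzothiazol-2-yl and 1-methyl-1H-benzimidazol-2-yl are separated by a modest step beyond the scatter (a 2.1-fold lower number from compound 3 to compound 4 (0.33 log units; beyond the scatter)), so the exact aromatic group counts at this position. Going by these compounds alone, the widest gap so far sets the oxan-4-yl compound apart from the new one (a 4.4-fold lower number from compound 2 to compound 4 (0.64 log units; beyond the scatter)), and compound 2 remains the only compound clearly above all the others.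

Going by these compounds, whether a single aromatic ring such as phenyl, or a carbamoyl group carrying a piperidine or a longer chain, would read like compound 1 or like compound 2 remains open. Nothing given here accounts for the size of these steps.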